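Swapping the substituent on the aromatic nitrogen

This account rests on a few compounds, and the source may have more. Where it says the series, first, only, none or still open, it means among the compounds named here.

Three compounds share one core and differ only in the group on the aromatic nitrogen. In an assay on Prostate gland for inhibition of steroid 5-alpha-reductase (Rattus norvegicus) (on this read-out lower numbers stand for stronger inhibition and higher numbers for weaker inhibition), compound 1 `CCCn1ccc2cc(/C(C)=C/C(=O)Nc3ccccc3OCCCC(=O)O)ccc21` gives 190 nM, compound 2 `C/C(=C\C(=O)Nc1ccccc1OCCCC(=O)O)c1ccc2c(ccn2Cc2ccc(C(C)(C)C)cc2)c1` gives 170 nM, and compound 3 `COc1ccc(Cn2ccc3cc(/C(C)=C/C(=O)Nc4ccccc4OCCCC(=O)O)ccc32)cc1` gives 480 nM, the highest of the three numbers. Compound 4 `C/C(=C\C(=O)Nc1ccccc1OCCCC(=O)O)c1ccc2c(ccn2C(c2ccccc2)C(C)C)c1` is not yet measured; it carries 2-methyl-1-phenylpropyl in place of 4-methoxybenzyl on an aromatic nitrogen. Among the compounds with values here, two measured steps bear on this change: a 2.8-fold higher number from compound 2 to compound 3 (0.45 log units; beyond the scatter), and a 2.5-fold higher number from compound 1 to compound 3 (0.40 log units; beyond the scatter), whereas a 1.1-fold lower number from compound 1 to compound 2 (0.05 log units; within the scatter). Taking away the methoxy while keeping a phenyl-bearing group on the nitrogen is therefore expected to bring the number back toward the region of compound 1 and compound 2, roughly a 2.2-fold lower number from compound 3 to compound 4 (0.34 log units; beyond the scatter). Compound 4 is accordingly estimated at 220 nM, with a likely range from 100 nM to 500 nM.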

Compound 4, half-maximal inhibitory concentration: 25 nM
The estimate for compound 4 lay 8.8-fold (0.94 log units) above the measured number, outside the stated range (below it).
By their numbers in this assay, from the lowest: compound 4; then compounds 2 and 1 (each within the scatter of the next); then compound 3.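

Within the data shown here, the group on the aromatic nitrogen can move the number much further than the earlier compounds suggested: in this assay, 2-methyl-1-phenylpropyl gives a 19-fold lower number from compound 3 to compound 4 (1.28 log units; beyond the scatter) against 4-methoxybenzyl, a 6.8-fold lower number from compound 2 to compound 4 (0.83 log units; beyond the scatter) against 4-(tert-butyl)benzyl and a 7.6-fold lower number from compound 1 to compound 4 (0.88 log units; beyond the scatter) against propyl. Propyl and 4-(tert-butyl)benzyl had stood within the scatter of each other, yet compound 4 lies clearly below both, so this position is not flat. Nothing available explains the gain.

The compounds shown do not separate the contribution of the phenyl from that of the branched chain. Unsubstituted benzyl, 1-phenylethyl and cyclohexylmethyl on the same nitrogen would help to separate them.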